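Amide Substituent Series: Paw Edema Inhibition Working Notes

The source may hold more compounds than are shown below. What is called first, only, known or untested is meant among the compounds shown, and "the series" means these compounds.

Measured so far in a functional assay on the whole organism (strain Wistar) for inhibition, with Rattus norvegicus as the target, read by paw edema, with stated times of 60 min and 2 h, at a dose of 100 mg/kg by the oral route; a lower number here means less inhibition, a higher number more inhibition at the dose given (going by the name of the read-out):
compound 1 `CCNC(=O)CC1CCc2cc(OC)c(OC)cc21` gives 26%
compound 2 `COc1cc2c(cc1OC)C(CC(=O)NC(C)C)CC2` gives 37%
compound 3 `COc1cc2c(cc1OC)C(CC(=O)NC1CCCC1)CC2` gives 52%

Compound 3 stands highest of the three numbers. Its nearest neighbour is compound 2, the gap being a number 15 percentage points higher from compound 2 to compound 3 (beyond the scatter); the furthest is compound 1, the gap being a number 26 percentage points higher from compound 1 to compound 3 (beyond the scatter). The remaining step, a number 11 percentage points higher from compound 1 to compound 2 (beyond the scatter), is likewise beyond the scatter.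

Compound 4 `COc1cc2c(cc1OC)C(CC(=O)NCCO)CC2` has not been measured. Its difference from compound 3: 2-hydroxyethyl in place of cyclopentyl on an amide-type nitrogen.

All three measured steps concern the group on the amide-type nitrogen, so all three bear on this change. Among compounds 1, 2 and 3 the group with more heavy atoms on that nitrogen went with more inhibition, and none of the three goes against this. Among the compounds with values here, the 2-hydroxyethyl group has no counterpart among the measured compounds, and the effect of its hydrogen-bond donor and acceptor is not known from these data. By heavy-atom count it lies closest to the ethyl of compound 1, so a downward step in this assay beyond the scatter is expected: a number 22 percentage points lower from compound 3 to compound 4 (beyond the scatter). Compound 4 is therefore estimated at 30%, with a range from 15% to 45%.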

Compound 4, a percentage reported as inhibition, in the whole organism at one dose (the size of the read-out at that dose, not a potency): 0%
Estimate against measurement, compound 4: 30 percentage points above; measured number outside the range, below it.
By their numbers in this assay, from the lowest: compound 4; then compound 1; then compound 2; then compound 3.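

The 2-hydroxyethyl group breaks the link seen among compounds 1, 2 and 3 between more heavy atoms on the amide-type nitrogen and more inhibition in this assay: against the cyclopentyl group the change gives a number 52 percentage points lower from compound 3 to compound 4 (beyond the scatter), and against the isopropyl group it gives a number 37 percentage points lower from compound 2 to compound 4 (beyond the scatter). Within the data shown here, the cleanest reading comes from the ethyl group, where the only change is hydroxy in place of hydrogen on the chain, and this alone gives a number 26 percentage points lower from compound 1 to compound 4 (beyond the scatter), so a larger group on this nitrogen does not by itself bring more inhibition, and compound 4 goes against the earlier pattern. The data hold no measurement that would explain the effect of the hydroxy group at this position.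

The compounds shown leave open whether the loss follows the free hydroxy group or any heteroatom on the chain, a question that a 2-methoxyethyl, a 2-aminoethyl or a carboxymethyl group on the same nitrogen would address. Also open, going by these compounds, is whether a hydroxy group has the same effect on a larger group, as in a hydroxycyclopentyl group or a longer chain such as 4-hydroxybutyl.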